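A few compounds are considered here, and "the series" means these few. Any claim that something is new, unique, unknown or untested is made for them only; others in the source may bear on it.

Measured so far in an ADME assay for permeability, using PAMPA, with a stated time of 30 min, at pH 7.4; a higher number here means that the compound crosses the layer faster, a lower number that the compound crosses the layer more slowly:
compound 1 `Fc1ccc(-c2ccc3c(NCCCNCc4ccco4)ccnc3c2)cc1` gives 237 10^-6 cm/s
compound 2 `Fc1ccc(Cc2ccc3c(NCCCNCc4ccco4)ccnc3c2)c(Cl)c1` gives 23 10^-6 cm/s

Within the data shown here, compound 2 stands lowest of the two numbers in this assay; its nearest neighbour is compound 1, separated by the single measured step, a 10-fold lower number from compound 1 to compound 2 (1.01 log units; beyond the scatter). Compound 3 `FC(F)(F)c1ccc(-c2ccc3c(NCCCNCc4ccco4)ccnc3c2)cc1` differs from compound 2 as follows: 4-(trifluoromethyl)phenyl in place of 2-chloro-4-fluorobenzyl on an aromatic carbon. Among the measured compounds shown here, the only step that bears on this is a 10-fold lower number from compound 1 to compound 2 (1.01 log units; beyond the scatter), which runs the opposite way on the same aromatic carbon and was large. A rise of comparable size is therefore expected, a 7.8-fold higher number from compound 2 to compound 3 (0.89 log units; beyond the scatter). For compound 3 the estimate in this assay is 180 10^-6 cm/s, with a range of 80 10^-6 cm/s to 350 10^-6 cm/s.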

Compound 3, apparent permeability: 237 10^-6 cm/s
The estimate for compound 3 lay 1.3-fold (0.12 log units) below the measured number; the measured number falls inside the stated range.
By their numbers in this assay, from the lowest: compound 2; then compounds 1 and 3 (each within the scatter of the next).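

In this assay, among these compounds, the change to 4-(trifluoromethyl)phenyl gives a 10-fold higher number from compound 2 to compound 3 (1.01 log units; beyond the scatter) and sets compound 2 apart as the only compound here with a benzyl group at this aromatic carbon. Trifluoromethyl in place of fluoro gives no change at the digits printed from compound 1 to compound 3 (within the scatter) and is the first change at this position that leaves the number where it was. No measurement on hand explains either step.

As far as these compounds go, whether the low number of compound 2 goes with the benzyl carbon or with the chloro substituent stays open, and 4-fluorobenzyl or 2-chloro-4-fluorophenyl would separate the two. Also open, from the compounds shown here alone, is how an amine or a carboxylic acid on the phenyl ring would read.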